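The source may hold more compounds than are shown below. What is called first, only, known or untested is meant among the compounds shown, and "the series" means these compounds.

Compound 2 `C=C1C(=O)O[C@@H]2CC(C)=C([C@@H](C)CCCOC(C)=O)[C@@H](OC(=O)COc3ccc(C(C)=O)cc3)[C@H]12` gives 43900 nM in a functional assay on HeLa cells (Homo sapiens) for cytotoxicity, read by sulforhodamine B assay, with a stated time of 72 h (a higher number here means a weaker inhibitor, a lower number a stronger inhibitor), the highest of the two numbers at hand; its nearest neighbour, compound 1 `C=C1C(=O)O[C@@H]2CC(C)=C([C@@H](C)CCCOC(C)=O)[C@@H](OC(=O)CN3CCCCC3)[C@H]12`, gives 10300 nM in this assay. Compound 3 `C=C1C(=O)O[C@@H]2CC(C)=C([C@@H](C)CCCOC(C)=O)[C@@H](OC(=O)COc3ccc([N+](=O)[O-])cc3[N+](=O)[O-])[C@H]12` in this assay reaches the limit > 100000 nM, a limit and not a number. The step of a 4.3-fold higher number from compound 1 to compound 2 (0.63 log units; beyond the scatter) was modest, and the step of an at least 2.2-fold higher number from compound 2 to compound 3 (0.35 log units; beyond the scatter) was at least modest, the second ending at the limit of > 100000 nM in this assay, at which 1 of the 3 values shown sits. Compound 4 `C=C1C(=O)O[C@@H]2CC(C)=C([C@@H](C)CCCOC(C)=O)[C@@H](OC(=O)c3ccc([N+](=O)[O-])cc3)[C@H]12` is reached from compound 2 through (4-nitrophenyl in place of (4-acetylphenoxy)methyl on a carbonyl carbon). Neither measured step covers this change, since both alter only the group attached to the chain that compound 4 loses. Compound 4 is therefore expected to give about 50000 nM, between 15000 nM and 150000 nM. The step of a 1.1-fold higher number from compound 2 to compound 4 (0.06 log units; within the scatter) is thus expected to stay within the scatter.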

Compound 4, half-maximal inhibitory concentration: 11300 nM
For compound 4 the middle estimate is 4.4-fold (0.65 log units) above the measured one; the measured number lies below the stated range.
By their numbers in this assay, from the lowest: compounds 1 and 4 (each within the scatter of the next); then compound 2. At a limit, above all of these: compound 3.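

In this assay, within the data shown here, the group on the carbonyl carbon itself proves open to change: 4-nitrophenyl in place of (4-acetylphenoxy)methyl gives a 3.9-fold lower number from compound 2 to compound 4 (0.59 log units; beyond the scatter), whereas the earlier steps, which altered only the end of the chain, both went upward. Against the piperidine, the result is a 1.1-fold higher number from compound 1 to compound 4 (0.04 log units; within the scatter), so 4-nitrophenyl and (piperidin-1-yl)methyl cannot be told apart at this place. Nothing measured here gives a cause for these steps. The compounds shown leave open whether the loss of the chain or the nitro group carries the change, and how a plain phenyl or a 4-aminophenyl on the carbonyl carbon would fare.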